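A few compounds are considered here, and "the series" means these few. Any claim that something is new, unique, unknown or untested is made for them only; others in the source may bear on it.

Measured so far:
- compound 1 `CCCn1c(=O)c2nc(CC(C)(C)C)[nH]c2n(CCC)c1=O` — 49 nM
- compound 2 `CCCn1c(=O)c2nc([C@@H]3CC4C=CC3C4)[nH]c2n(CCC)c1=O` — 4.3 nM

In an assay on cell membranes for binding affinity to adenosine receptor A1 (Cavia porcellus), read by radioligand binding (a higher number here means a weaker inhibitor, a lower number a stronger inhibitor), compound 1 gives 49 nM, the highest of the two numbers seen so far, which in this assay means it is the weaker of the two binders. Compound 2, in this assay, gives 4.3 nM. For the measured compounds named here, the only step measured so far is the one from compound 1 to compound 2: an 11-fold lower number from compound 1 to compound 2 (1.06 log units; beyond the scatter). There a pair of carbon rings took the place of an open carbon chain.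

The new compound, compound 3 `CCCn1c(=O)c2nc(-c3ccco3)[nH]c2n(CCC)c1=O`, is changed from compound 1 at the same aromatic carbon of the shared core, the one sitting between two ring nitrogen atoms: furan-2-yl in place of neopentyl on an aromatic carbon. Going by the values given here, no measured step shows this exact exchange. The step to compound 2 bears on it only loosely, since it too replaced the neopentyl group with a ring-containing group and brought a much lower number. Here the entering group is a small aromatic ring carrying one hydrogen-bond acceptor rather than a larger saturated pair of rings, so a smaller step is expected. The number for compound 3 in this assay is therefore estimated at 20 nM, within a range from 5 nM to 80 nM, meaning an expected step of a 2.5-fold lower number from compound 1 to compound 3 (0.39 log units; beyond the scatter).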

Compound 3, inhibition constant: 560 nM
The estimate for compound 3 lay 28-fold (1.45 log units) below the measured number, outside the stated range (above it).
By their numbers in this assay, from the lowest: compound 2; then compound 1; then compound 3.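

In this assay, the aromatic carbon between two ring nitrogen atoms now shows that a ring at this place does not by itself lower the number: furan-2-yl in place of neopentyl moves it the other way (an 11-fold higher number from compound 1 to compound 3 (1.06 log units; beyond the scatter)), against the direction seen with the ring-containing group of compound 2. Neopentyl and furan-2-yl each hold 5 heavy atoms, so groups with the same heavy-atom count can differ here by far more than the scatter, and the two ring-containing groups of this set lie furthest apart (a 130-fold higher number from compound 2 to compound 3 (2.11 log units; beyond the scatter)). No measurement is available to explain why furan-2-yl gives the weakest binder of the three.

On these data alone, compound 3 is the only one of the three with an aromatic ring at this place, so it remains open whether phenyl would behave like furan-2-yl or whether the result belongs to furan-2-yl alone. As far as these compounds go, it is also open where a single saturated ring such as cyclopentyl would fall, and whether thiophen-2-yl, with sulfur in place of the ring oxygen, would stay close to compound 3.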